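The compounds below may be only part of what the source reports. "The series", "measured", "known", "first", "only" and "open" are said of these compounds alone.

Measured in a functional assay on L02 cells (Homo sapiens) for inhibition, read by Griess assay, with stated times of 1 h and 24 h; a higher number here means a weaker inhibitor, a lower number a stronger inhibitor:

- Compound 1 `CCCc1nn(C)c2c(NC3CC3)nc(CCc3cccnc3)nc12`: 564000 nM
- Compound 2 `CNc1nc(/C=C/c2ccccc2)nc2ccsc12`: > 1000000 nM (a limit, not a number)
- Compound 3 `CCCCNc1nc(/C=C/c2ccccc2)nc2ccsc12`: > 1000000 nM (a limit, not a number)

Compound 3 has no exact value, only the limit > 1000000 nM. The same is true of compound 2, so the evidence is thin: the limit of > 1000000 nM in this assay, at which 2 of the 3 values shown sit. Only compound 1 has a true number, and it carries a different core.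

Compound 4 `C(=C/c1nc(Nc2ccccc2)c2sccc2n1)\c1ccccc1` keeps the core of compound 3 and changes one group: phenyl in place of butyl on a nitrogen on an aromatic ring. The butyl chain gives way to a phenyl ring on the same nitrogen.

For the measured compounds named here, the one measured step that bears on this also concerns that nitrogen: a step that the two limits leave unreadable from compound 2 to compound 3. Both of its ends are limits, so it gives no size to carry over and no direction to follow. With no readable guide, no clear change is expected in this assay, and compound 4 will probably also stay weak, quite possibly reported only as a limit. The estimated step is a number no higher from compound 3 to compound 4 (the limit leaves the size open). Compound 4 is expected to give about 1000000 nM, with an estimated range of 300000 nM to 3000000 nM.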

Compound 4, half-maximal inhibitory concentration: > 1000000 nM
Compound 4: no number, only a limit; the forecaster's own chance of this, stated with the estimate: 65%; the middle value sits exactly at the limit.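

For the compounds shown here, compound 2, compound 3 and compound 4 each carry only a limit in this assay, not a number, so no step among them can be read in size or direction. The compounds shown leave open whether changing the group on that nitrogen alters inhibition at all, since all three stop at the same point: the limit of > 1000000 nM in this assay, at which 3 of the 4 values shown sit.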